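The source may hold more compounds than are shown below. What is called first, only, known or untested is meant among the compounds shown, and "the series" means these compounds.

Of the compounds shown here, three built on one shared core have been measured in a functional assay on the whole organism (strain Wistar) for inhibition, with Rattus norvegicus as the target, read by paw edema, with a stated time of 30 min, at a dose of 10 mg/kg by the intraperitoneal route; a higher number here means more inhibition at the dose given (going by the name of the read-out), a lower number less inhibition. Compound 1 `O=C(N/N=C/c1cccc(Cl)c1)c1cccnc1Nc1cccc(C(F)(F)F)c1` gives 77.8%. Compound 2 `O=C(N/N=C/c1ccc(O)cc1)c1cccnc1Nc1cccc(C(F)(F)F)c1` gives 59.3%, and compound 3 `O=C(N/N=C/c1ccc(O)c(O)c1)c1cccnc1Nc1cccc(C(F)(F)F)c1` gives 51.4%. Compound 3 therefore stands lowest of the three numbers, although the step of a number 7.9 percentage points lower from compound 2 to compound 3 (within the scatter) lies within the scatter, so compound 2 and compound 3 cannot be ranked against each other. The step of a number 26.4 percentage points lower from compound 1 to compound 3 (beyond the scatter) lies beyond the scatter, as does a number 18.5 percentage points lower from compound 1 to compound 2 (beyond the scatter).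

Compound 4 `COc1cccc(/C=N/NC(=O)c2cccnc2Nc2cccc(C(F)(F)F)c2)c1` is the unmeasured member. It differs from compound 3 in one place: 3-methoxyphenyl in place of 3,4-dihydroxyphenyl on a carbon with a double bond to nitrogen The two earlier steps that altered this same ring bear on the question. Both rings carrying hydroxy groups gave lower numbers than the 3-chlorophenyl ring of compound 1, and the ring of compound 4 carries no hydroxy group at all. Because compound 1 gives 77.8% while compound 3 gives 51.4%, compound 4 is expected to move back toward the upper end of that span. The step of a number 16.6 percentage points higher from compound 3 to compound 4 (beyond the scatter) is the expected outcome. Compound 4 is thus estimated at 68%, with a likely range from 55% to 80%.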

Compound 4, a percentage reported as inhibition, in the whole organism at one dose (the size of the read-out at that dose, not a potency): 52.8%
For compound 4 the middle estimate is 15.2 percentage points above the measured one; measured number below the stated range.
By their numbers in this assay, from the lowest: compounds 3, 4 and 2 (each within the scatter of the next); then compound 1.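

Taking away both hydroxy groups does not bring the number back up: in this assay the 3-methoxyphenyl ring of compound 4 cannot be told apart from the rings that carry hydroxy groups (a number 1.4 percentage points higher from compound 3 to compound 4 (within the scatter); a number 6.5 percentage points lower from compound 2 to compound 4 (within the scatter)). Within the data shown here, the one step here beyond the scatter is methoxy in place of chloro on an aromatic carbon (a number 25 percentage points lower from compound 1 to compound 4 (beyond the scatter)). Compound 4 has no hydroxy group yet groups with compound 2 and compound 3, so the lack of a hydroxy group alone does not match the number of compound 1, and nothing available here explains the gap between chloro and methoxy.

Still open, from the compounds shown here alone, is whether the number of compound 1 depends on chloro itself or would also appear with another group on that aromatic carbon, such as bromo, a nitrile or an amine. A plain phenyl ring with no added group would also give a baseline against which chloro, methoxy and hydroxy could each be read.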